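The source may report more compounds than this note shows. Statements on the series, on what has been measured and on what is new or still open speak of the compounds shown alone.

Compound 1 `O=[N+]([O-])c1cccc(-c2nn(-c3ccccc3)cc2C(Nc2nc3ccccc3s2)c2c(O)ccc3ccccc23)c1`: 32000 nM
Compound 2 `COc1ccc2nc(NC(c3cn(-c4ccccc4)nc3-c3ccc(F)cc3)c3c(O)ccc4ccccc34)sc2c1`: 33600 nM

Both compounds were tested in a functional assay on A549 cells (Homo sapiens) for antiproliferative activity, read by MTT assay, with a stated time of 48 h; on this read-out lower numbers stand for stronger inhibition and higher numbers for weaker inhibition. Compound 2 gives 33600 nM, and compound 1 gives 32000 nM. Within the data shown here, these two values lie within the scatter of each other, so compound 2 stands level with the only other compound measured.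

The next compound to be tested is compound 3 `COc1ccc2nc(NC(c3cn(-c4ccccc4)nc3-c3cccc([N+](=O)[O-])c3)c3c(O)ccc4ccccc34)sc2c1`. It keeps the rest of compound 2 and carries 3-nitrophenyl in place of 4-fluorophenyl on an aromatic carbon of a five-membered aromatic ring with 2 nitrogen (3-nitrophenyl in place of 4-fluorophenyl on an aromatic carbon).

Among the measured compounds shown here, no measured pair shows what this swap alone does, so any forecast rests on thin evidence. The 3-nitrophenyl group also occurs in compound 1, which gives 32000 nM. For that reason, no change beyond the scatter is expected, in either direction, and the expected size of the change is a 1.1-fold lower number from compound 2 to compound 3 (0.05 log units; within the scatter). The estimate for compound 3 is 30000 nM, with an expected range from 13000 nM to 65000 nM.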

Compound 3, half-maximal inhibitory concentration: 52200 nM
Compound 3: middle estimate off by 1.7-fold (0.24 log units), on the low side; the range from low to high includes it.
By their numbers in this assay, from the lowest: compounds 1, 2 and 3 (each within the scatter of the next).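

In this assay, among these compounds, putting 3-nitrophenyl in place of 4-fluorophenyl on the aromatic carbon next to the ring nitrogen gives a 1.6-fold higher number from compound 2 to compound 3 (0.19 log units; within the scatter) and so provides the first direct reading of this swap, which stays within the scatter. The same compound also provides a second single-change comparison: with 3-nitrophenyl held constant, methoxy in place of hydrogen on an aromatic carbon gives a 1.6-fold higher number from compound 1 to compound 3 (0.21 log units; within the scatter) and this step also stays within the scatter, so neither change separates its two compounds on this read-out. No separate measurement is available to link either step to a property of the groups involved.

These compounds leave open whether a different group at the same carbon, such as a phenyl ring carrying an amine or a carboxylic acid, or a plain methyl group, would give a step beyond the scatter. They also leave open whether a hydroxyl group or a chlorine atom in place of the methoxy group would separate from compound 1 and compound 3 on this read-out.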